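A few compounds are considered here, and "the series" means these few. Any claim that something is new, unique, unknown or untested is made for them only; others in the source may bear on it.

In a functional assay on MCF7 cells (Homo sapiens) for cytotoxicity, read by MTT assay, with a stated time of 96 h (on this read-out lower numbers stand for stronger inhibition and higher numbers for weaker inhibition), compound 2 `COc1cc(C(=O)c2cn(-c3cccc(F)c3)cc2-c2ccccc2[N+](=O)[O-])cc(OC)c1OC` gives 190 nM, level with compound 1 `COc1cc(C(=O)c2cn(-c3ccccc3)cc2-c2ccccc2Br)cc(OC)c1OC` at 190 nM. Together they hold the highest of the three numbers. Compound 3 `COc1cc(C(=O)c2cn(-c3ccc(C)cc3)cc2-c2ccccc2F)cc(OC)c1OC` stands lower at 44 nM, beyond the scatter, but it differs from compound 2 in more than one place and offers only weak guidance. Compound 4 `COc1cc(C(=O)c2cn(-c3ccc(F)cc3)cc2-c2ccccc2[N+](=O)[O-])cc(OC)c1OC` has the same atoms as compound 2, joined differently: 4-fluorophenyl in place of 3-fluorophenyl on an aromatic nitrogen, with 4-fluorophenyl in place of 3-fluorophenyl on an aromatic nitrogen. For the measured compounds named here, no measured single-place step exists in this assay to calibrate this change. The expected result is no change beyond the scatter, with a slight lean toward a lower number, as the estimated 1.5-fold lower number from compound 2 to compound 4 (0.16 log units; within the scatter). For compound 4 the estimated value is 130 nM, with an expected range of 45 nM to 380 nM.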

Compound 4, half-maximal inhibitory concentration: 38 nM
Estimate against measurement, compound 4: 3.4-fold (0.53 log units) above, and the stated range ends above it.
By their numbers in this assay, from the lowest: compounds 4 and 3 (each within the scatter of the next); then compounds 1 and 2 (each within the scatter of the next).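

On the aromatic nitrogen, 4-fluorophenyl in place of 3-fluorophenyl gives a 5.0-fold lower number from compound 2 to compound 4 (0.70 log units; beyond the scatter) in this assay. For the compounds shown here, this is the first single-place step, and it shows that moving the fluorine within this phenyl group, with the atoms unchanged, is enough to shift the number beyond the scatter. Nothing measured here accounts for the step.

From the compounds shown here alone, whether the step holds with a group other than 2-nitrophenyl on the ring stays open. So does what 4-chlorophenyl or 4-methoxyphenyl would give on the same nitrogen.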